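Moving From Compound 3 to Compound 4: Expected Lipophilicity

The source may report more compounds than this note shows. Statements on the series, on what has been measured and on what is new or still open speak of the compounds shown alone.

The compounds share one core, seen in compound 1 `Cc1cc(C(=O)O)nn1Cc1cc(Br)ccc1OCc1ccccc1`, which gives 1.2 in a physicochemical assay for lipophilicity, at pH 7.4; on this read-out lower numbers stand for lower lipophilicity and higher numbers for higher lipophilicity. Compound 2 `Cc1cc(C(=O)O)nn1C(C)c1cc(Cl)ccc1OCc1ccccc1` gives 1. Compound 3 `Cc1cc(C(=O)Nc2ccccc2)nn1Cc1cc(Cl)ccc1OCc1ccccc1` is reported only as a limit of the assay, > 3.7, and this is the limit of > 3.7 in this assay, at which 1 of the 3 values shown sits. Compound 4 `Cc1cc(NC(=O)C(C)C)nn1Cc1cc(Cl)ccc1OCc1ccccc1` differs from compound 3 in one place: (isopropylcarbonyl)amino in place of phenylcarbamoyl on an aromatic carbon. A group with no ring takes the place of one carrying a six-membered aromatic ring of carbon only, so a fall in this assay beyond the usual scatter is expected, though the starting point is a limit rather than a number. The expected step is a number at least 0.70 log units lower from compound 3 to compound 4 (beyond the scatter). Compound 4 is estimated to give 3, with a likely span from 2.3 to 3.7.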

Compound 4, distribution coefficient: > 3.7
Compound 4: only a limit was reported; the forecaster's own chance of this, stated with the estimate: 10%; at least 0.70 log units between middle value and limit.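

No step from compound 3 to compound 4 can be read in this assay, since both are reported only as a limit: the limit of > 3.7 in this assay, at which 2 of the 4 values shown sit.

As far as these compounds go, whether (isopropylcarbonyl)amino in place of phenylcarbamoyl shifts this read-out at all, and in which direction, stays open.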